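Bromo to Nitro: Expectations for Compound 3

A few compounds are considered here, and "the series" means these few. Any claim that something is new, unique, unknown or untested is made for them only; others in the source may bear on it.

In a functional assay on HepG2 cells (Homo sapiens) for cytotoxicity, read by ELISA, with stated times of 2 h and 48 h (a higher number here means a weaker inhibitor, a lower number a stronger inhibitor), compound 2 (`Cc1ccc(S(=O)(=O)Nc2ccc(C(=O)/C=C/c3ccc(Br)cc3)cc2)cc1`) stands at 26800 nM with one measured neighbour, compound 1 (`C/C(=N/NC(=O)c1sc2c(c1N)CCCC2)c1ccc(NS(=O)(=O)c2ccc(C)cc2)cc1`) at 20000 nM, a gap that lies within the usual scatter. The two compounds therefore cannot be ranked against each other.

Compound 3 (`Cc1ccc(S(=O)(=O)Nc2ccc(C(=O)/C=C/c3ccc([N+](=O)[O-])cc3)cc2)cc1`) has nitro in place of bromo on an aromatic carbon, para to a large group (nitro in place of bromo on an aromatic carbon). Going by the values given here, no measured pair shows this change, so the data offer no direct guide to its size in this assay. No step beyond the scatter is expected, in either direction, and compound 2 at 26800 nM serves as the anchor for that expectation. The estimated change, a 1.2-fold lower number from compound 2 to compound 3 (0.09 log units; within the scatter), stays inside the scatter. For compound 3 the expected value is 22000 nM (estimated range 9000 nM to 50000 nM).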

Compound 3, half-maximal inhibitory concentration: 20500 nM
Compound 3: the middle estimate sits 1.1-fold (0.03 log units) above what was measured, within the range that was stated.
By their numbers in this assay, from the lowest: compounds 1, 3 and 2 (each within the scatter of the next).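

In this assay, going by these compounds alone, the one measured pair at this position gives a 1.3-fold lower number from compound 2 to compound 3 (0.12 log units; within the scatter) for nitro in place of bromo on an aromatic carbon, para to a large group. This change, which puts three heavy atoms where one stood and brings two hydrogen-bond acceptors by the count, therefore leaves compound 3 and compound 2 inseparable in this read-out, something compound 1, which differs from compound 2 in more than one place, could not show. Nothing available bears on why the two compounds read alike.

On these data alone, only bromo and nitro are compared at this position, so whether any group placed here can shift the reading remains open. An amine or a carboxylic acid in the same place would test whether the position stays this indifferent to groups of another kind.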